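Diselenides and a selenocyanate: an aryl carbamate exchange

This account rests on a few compounds, and the source may have more. Where it says the series, first, only, none or still open, it means among the compounds named here.

Measured compounds:
compound 1 `CC(C)COC(=O)Nc1ccc([Se][Se]c2ccc(NC(=O)OCC(C)C)cc2)cc1` — 29000 nM
compound 2 `O=C(Nc1ccc([Se][Se]c2ccc(NC(=O)OCc3ccccc3)cc2)cc1)OCc1ccccc1` — 23800 nM
compound 3 `CCCCCCOC(=O)Nc1ccc([Se]C#N)cc1` — 23600 nM

In a functional assay on HTB-54 cells (Homo sapiens) for cytotoxicity, read by MTT assay, with a stated time of 72 h (a higher number here means a weaker inhibitor of growth, a lower number a stronger inhibitor of growth), compound 1 gives 29000 nM, compound 2 gives 23800 nM and compound 3 gives 23600 nM. Compound 3 sits at one end of these three numbers, but its gaps to compound 2 and to compound 1 are both within the scatter, so the three compounds stand on a par in this assay.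

Compound 4 `N#C[Se]c1ccc(NC(=O)Oc2ccccc2)cc1` is not yet measured. It differs from compound 3 by phenyl in place of hexyl on an oxygen next to a carbonyl group. Within the data shown here, no measured pair in this set shows what such an exchange does. With the three measured compounds all falling in one narrow band, there is no basis for expecting a move in either direction, and the estimate for compound 4 is therefore set close to compound 3, with a wide range. The expected step from compound 3 to compound 4 is a 1.1-fold lower number from compound 3 to compound 4 (0.03 log units; within the scatter), which is none beyond the scatter. Compound 4 is estimated at 22000 nM, between 8000 nM and 60000 nM.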

Compound 4, concentration for 50% growth inhibition: 26200 nM
Compound 4: middle estimate off by 1.2-fold (0.08 log units), on the low side; measured number inside the range.
By their numbers in this assay, from the lowest: compounds 3, 2, 4 and 1 (each within the scatter of the next).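

Phenyl in place of hexyl on an oxygen next to a carbonyl group, the first exchange in this set that can be read as a single change, gives a 1.1-fold higher number from compound 3 to compound 4 (0.05 log units; within the scatter) in this assay for this pair. At this position, then, a six-membered aromatic ring of carbon only can take the place of an open chain of the same heavy-atom count without a step beyond the scatter. Nothing available here gives a reason for this result.

The compounds shown leave open whether a different group on this oxygen, such as methyl, a longer chain, or a chain ending in an amine or a carboxylic acid, would bring a step beyond the scatter. They also leave open whether the same exchange would read alike on the diselenide compounds.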